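This account rests on a few compounds, and the source may have more. Where it says the series, first, only, none or still open, it means among the compounds named here.

Three measured compounds share a core in which a sulfur-linked pair of aromatic rings carries an oxime on one side and a fluorine with an oxygen-containing six-membered ring on the other. Compound 1, `CC(C)/C(=N\O)c1ccc(Sc2cc(F)cc(C3CCOCC3)c2)cc1`, gives 300 nM in a functional assay (blood) for inhibition, with Homo sapiens as the target; a higher number here means a weaker inhibitor, a lower number a stronger inhibitor. Compound 2, `COC1(c2cc(F)cc(Sc3ccc4c(c3)CC/C4=N\O)c2)CCOCC1`, gives 290 nM in this assay, and compound 3, `C/C(=N\OCC(O)CO)c1ccc(S(=O)(=O)c2cccc(C3CCOCC3)c2)cc1`, gives 160 nM. All three numbers lie within the scatter of one another, so compound 1 stands apart from neither compound 2 nor compound 3.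

Compound 4 is `CCOC(=O)CO/N=C(\C)c1ccc(Sc2cc(F)cc(C3CCOCC3)c2)cc1`. It differs from compound 1 in one place: a group of 10 heavy atoms (6 carbon, 1 nitrogen, 3 oxygen; no ring) in place of a group of 6 heavy atoms (4 carbon, 1 nitrogen, 1 oxygen; no ring), on an aromatic carbon. The free oxime hydroxyl of compound 1 is thus capped by a short ethyl ester chain. Compound 3 already carries an oxime whose hydroxyl is replaced by a different chain and gives 160 nM, a value within the scatter of compound 1, so such a replacement alone is not expected to move the number beyond the scatter. Compound 4 is therefore estimated to give 250 nM, between 100 nM and 700 nM, an expected step of a 1.2-fold lower number from compound 1 to compound 4 (0.08 log units; within the scatter) that stays within the scatter.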

Compound 4, half-maximal inhibitory concentration: 610 nM
Estimate against measurement, compound 4: 2.4-fold (0.39 log units) below; the range from low to high includes it.
By their numbers in this assay, from the lowest: compounds 3, 2 and 1 (each within the scatter of the next); then compound 4.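

Going by these compounds alone, this pair is the first in the set to differ in one place, so it gives the first direct reading at this position on the aromatic ring: in this assay the step is a 2.0-fold higher number from compound 1 to compound 4 (0.31 log units; beyond the scatter) and it lies just beyond the scatter. The position accepts the group of 10 heavy atoms, with 0 hydrogen-bond donors, in place of the group of 6 heavy atoms, with 1 hydrogen-bond donor, and inhibition is reduced only modestly. No measurement available here accounts for the step.

From the compounds shown here alone, it remains open whether capping the oxime hydroxyl or the rest of the change in the group accounts for the step, since the two groups differ in more than the ethyl ester chain. Also open, going by these compounds, is how a carboxylic acid or an amine at the end of that chain would compare with compound 1.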